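A few compounds are considered here, and "the series" means these few. Any claim that something is new, unique, unknown or untested is made for them only; others in the source may bear on it.

Measured compounds:
- compound 1, `COC(=O)C1=C(C)NC(=O)NC1c1cccs1`, 6% in an assay on membranes from CHO cells for displacement of a labelled ligand from adenosine receptor A1 (Homo sapiens), read by scintillation counting, with a stated time of 60 min, tested at 1 uM; a lower number here means less inhibition, a higher number more inhibition at the concentration tested (going by the name of the read-out)
- compound 2, `CC1=C(C(=O)OC(C)(C)C)C(c2cccs2)NC(=O)N1`, 26%
- compound 3, `CC1=C(C(=O)CC(C)C)C(c2cccs2)NC(=O)N1`, 19%

Compound 3 stands second highest of the three in this assay: its nearest neighbour is compound 2, whose value lies within the scatter of it, and its furthest is compound 1, which lies beyond the scatter below it. Compound 4, `CC1=C(C(=O)NC(C)C)C(c2cccs2)NC(=O)N1`, has not been measured. It differs from compound 3 by isopropylamino in place of isobutyl on a carbonyl carbon. For the measured compounds named here, the steps that bear on this change are the two other substitutions at the same carbonyl carbon: a number 13 percentage points higher from compound 1 to compound 3 (beyond the scatter) and a number 7 percentage points lower from compound 2 to compound 3 (within the scatter). Both are modest or within the scatter, so a change of similar size is expected for a number 4 percentage points lower from compound 3 to compound 4 (within the scatter), leaning slightly downward. Compound 4 is therefore estimated at 15%, within 3% to 30%.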

Compound 4, a percentage reported as inhibition, at one concentration (the size of the read-out at that concentration, not a potency): 2%
Beside the measured number, compound 4's estimate is 13 percentage points above it; the measured number lies below the stated range.
By their numbers in this assay, from the lowest: compounds 4 and 1 (each within the scatter of the next); then compounds 3 and 2 (each within the scatter of the next).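

In this assay the change at this carbonyl carbon is not neutral: isopropylamino in place of isobutyl gives a real drop (a number 17 percentage points lower from compound 3 to compound 4 (beyond the scatter)), and isopropylamino in place of tert-butoxy gives a larger one (a number 24 percentage points lower from compound 2 to compound 4 (beyond the scatter)). Against the methoxy group, isopropylamino makes no difference that can be told from scatter (a number 4 percentage points lower from compound 1 to compound 4 (within the scatter)). Nothing available accounts for this result. As far as these compounds go, it remains open whether the amide hydrogen matters, which a dimethylamino group on the same carbonyl carbon could test, and whether a longer chain on the amide nitrogen would restore inhibition.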